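Replacing a urea end group with a pyridine ring

The source may hold more compounds than are shown below. What is called first, only, known or untested is meant among the compounds shown, and "the series" means these compounds.

The compounds share one core, here carrying a methyl-amide side chain and an amidine-type end. Compound 1 `CN(C(=O)C[C@@H](N)CCCN=C(N)N)C1CN=C(NC(N)=O)NC1=O` gives 170 nM in a functional assay for inhibition, with Oryctolagus cuniculus as the target (a lower number here means a stronger inhibitor, a higher number a weaker inhibitor), the second highest of the three numbers: compound 2 `CN(C(=O)C[C@@H](N)CCCCN)C1CN=C(Nc2ncccn2)NC1=O` gives 380 nM, and compound 3 `CN(C(=O)C[C@@H](N)CCCCN)C1CN=C(Nc2ccc3ccccc3n2)NC1=O` gives 50 nM. Compound 2 and compound 3 differ in one place, quinolin-2-yl in place of pyrimidin-2-yl on an amine nitrogen, and that step read a 7.6-fold lower number from compound 2 to compound 3 (0.88 log units; beyond the scatter).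

Compound 4 `CN(C(=O)C[C@@H](N)CCCN=C(N)N)C1CN=C(Nc2ccccn2)NC1=O` differs from compound 1 by pyridin-2-yl in place of carbamoyl on an amine nitrogen. For the measured compounds named here, no measured pair covers exactly this change; the only nearby step swaps one aromatic ring for another on the same nitrogen, and compound 2 carries a different chain elsewhere, so it bears on the change only loosely. A modest step in either direction is the most that can be expected. Compound 4 is expected to give 150 nM, within 50 nM to 450 nM, which means an expected step of a 1.1-fold lower number from compound 1 to compound 4 (0.05 log units; within the scatter).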

Compound 4, half-maximal inhibitory concentration: 70 nM
Beside the measured number, compound 4's estimate is 2.1-fold (0.33 log units) above it; the range from low to high includes it.
By their numbers in this assay, from the lowest: compounds 3 and 4 (each within the scatter of the next); then compound 1; then compound 2.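

With the side chain held the same, changing the ureido group to (pyridin-2-yl)amino on this amine nitrogen gives a 2.4-fold lower number from compound 1 to compound 4 (0.39 log units; beyond the scatter) in this assay. The earlier step only exchanged one aromatic ring for another, whereas this one shows that carbamoyl, which has no ring, can give way to a six-membered aromatic ring without the inhibitor becoming weaker. The entering ring also has no hydrogen-bond donor, while the carbamoyl group has one, so a donor on this group is not needed to reach this level of inhibition, and nothing available explains why the number fell.

A phenyl ring on the same amine nitrogen would test whether the nitrogen atom of the pyridine ring matters. From the compounds shown here alone, it also remains open whether this change would give a similar step on the different chain carried by compound 2 and compound 3.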